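Trimming the Phenyl from the Amine of Compound 2

The source may hold more compounds than are shown below. What is called first, only, known or untested is meant among the compounds shown, and "the series" means these compounds.

Compound 1 `COc1ccc(-c2ccc3oc(NC4CCCCC4)nc3c2)cc1C` — 228 nM
Compound 2 `CN(c1ccccc1)c1nc2cc(-c3ccc4c(ccn4C)c3)ccc2o1` — 68 nM

Of the compounds shown here, two have been measured in an assay on HEK293 cells for inhibition of Fatty-acid amide hydrolase 1 (Homo sapiens), read by fluorescence; on this read-out higher numbers stand for weaker inhibition and lower numbers for stronger inhibition. Compound 1 gives 228 nM, and compound 2 gives 68 nM. Of these two numbers compound 2 has the lowest; the gap to compound 1 lies beyond the scatter of repeated measurements, so compound 2 is the stronger inhibitor of the pair.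

Compound 3 `CNc1nc2cc(-c3ccc4c(ccn4C)c3)ccc2o1` has not yet been measured. It differs from compound 2 in one place: hydrogen in place of phenyl on a nitrogen on an aromatic ring. The same difference, cut one bond further out, reads methyl(phenyl)amino to methylamino. Among the measured compounds shown here, no pair of measured compounds differing in just one place is available, so there is no measured step to lean on. Removing a whole aromatic ring from the amine is a sizeable cut, and the expectation is that the number in this assay rises by a step beyond the scatter.

For compound 3 the estimated outcome in this assay is 400 nM, within a range of 100 nM to 2000 nM, which means an expected step of a 5.9-fold higher number from compound 2 to compound 3 (0.77 log units; beyond the scatter).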

Compound 3, half-maximal inhibitory concentration: > 1000 nM
Compound 3: no number, only a limit; the forecaster's own chance of this, stated with the estimate: 10%; at least 2.5-fold (0.39 log units) between middle value and limit.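

In this assay compound 3 gives > 1000 nM, and this value is a limit of the assay, not a number. Going from phenyl to hydrogen on this nitrogen gives an at least 14-fold higher number from compound 2 to compound 3 (1.16 log units; beyond the scatter), the first step in this series that changes one place only, and it shows that inhibition depends heavily on the phenyl at this position, with methyl left on the nitrogen alone not enough to keep it. How far the number really rises stays unknown, and the reading rests on a single compound sitting at the edge of what the assay reports: the limit of > 1000 nM in this assay, at which 1 of the 3 values shown sits.

The compounds shown leave open whether an aromatic ring is what matters on this nitrogen, or whether a benzyl or a plain ethyl group in place of the phenyl would hold on to some of the inhibition. They also leave open what the methyl on the same nitrogen contributes, and whether cutting the phenyl has an equally large effect when the rest of the molecule is different, as on the core of compound 1.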